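The compounds below may be only part of what the source reports. "The series", "measured", "known", "first", "only" and "open" are said of these compounds alone.

Three compounds share one core and differ only at one aromatic carbon. Compound 1 `CCCCCc1cc(C)c(C(=O)N=C(N)N)cc1S(C)(=O)=O` carries a pentyl group there and in a functional assay for inhibition of sodium/hydrogen exchanger (Oryctolagus cuniculus) (a higher number here means a weaker inhibitor, a lower number a stronger inhibitor), compound 1 gives 27 nM. Compound 2 `Cc1cc(-c2ccc(Cl)cc2)c(S(C)(=O)=O)cc1C(=O)N=C(N)N` carries a 4-chlorophenyl group, and in this assay compound 2 gives 45 nM. Compound 3 `Cc1cc(-c2ccc(F)cc2)c(S(C)(=O)=O)cc1C(=O)N=C(N)N` carries a 4-fluorophenyl group, and in this assay compound 3 gives 36 nM, the second highest of the three numbers, within the scatter of both neighbours.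

Compound 4 `COc1cc(C)c(C(=O)N=C(N)N)cc1S(C)(=O)=O` is not yet measured. It differs from compound 3 in one place: methoxy in place of 4-fluorophenyl on an aromatic carbon

Within the data shown here, no measured step brings in a methoxy group, so the expectation rests on how tolerant this position has been. The step of a 1.3-fold higher number from compound 1 to compound 3 (0.12 log units; within the scatter) and the step of a 1.7-fold higher number from compound 1 to compound 2 (0.22 log units; within the scatter) exchanged a pentyl chain for an aryl ring without leaving the scatter, and a 1.3-fold lower number from compound 2 to compound 3 (0.10 log units; within the scatter) was likewise within it. Compound 4 is therefore expected to give 55 nM in this assay, with a range of 20 nM to 160 nM. That estimate means a step of a 1.5-fold higher number from compound 3 to compound 4 (0.18 log units; within the scatter), expected to stay near the scatter, leaning if anything toward a weaker inhibitor.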

Compound 4, half-maximal inhibitory concentration: 16 nM
Compound 4: middle estimate off by 3.4-fold (0.54 log units), on the high side; the measured number lies below the stated range.
By their numbers in this assay, from the lowest: compounds 4, 1, 3 and 2 (each within the scatter of the next, the first and the last beyond it).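

Among these compounds, the position proves less indifferent than the earlier compounds suggested: in this assay the exchanges among pentyl and the two aryl rings all stayed within the scatter, while methoxy on this aromatic carbon, ortho to a methylsulfonyl group, gives a 2.3-fold lower number from compound 3 to compound 4 (0.35 log units; beyond the scatter) and a 2.8-fold lower number from compound 2 to compound 4 (0.45 log units; beyond the scatter), both beyond it. Against the pentyl chain the same group gives a 1.7-fold lower number from compound 1 to compound 4 (0.23 log units; within the scatter), so methoxy separates from the two aryl-bearing compounds but not from compound 1, which is the exception to any reading of methoxy as better than every other group here. No measurement is at hand that would explain this difference.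

The compounds shown leave open whether an amine, a hydroxyl or an ethoxy group on this carbon would fall with methoxy. They also leave open whether a short chain such as ethyl, or an unsubstituted phenyl ring, would fall with pentyl or with the two halogenated aryl rings.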